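A few compounds are considered here, and "the series" means these few. Any claim that something is new, unique, unknown or untested is made for them only; others in the source may bear on it.

Measured so far in an ADME assay on HFF cells (Homo sapiens) for cytotoxicity, with a stated time of 8 days (a higher number here means that more compound is tolerated, a lower number that less compound is tolerated), with every value a limit and not a number:

compound 1 `CCOc1nc(N)nc2c1ncn2/C=C1/CC1(CO)CO` gives > 300000 nM as a limit
compound 2 `Nc1nc(OCc2ccccc2)c2ncn(/C=C3/CC3(CO)CO)c2n1` gives > 300000 nM as a limit
compound 3 `Nc1nc(NCc2ccccc2)c2ncn(/C=C3/CC3(CO)CO)c2n1` gives > 300000 nM as a limit

Compound 3 therefore has no number of its own and stands at the limit of the assay, where the other two measured compounds also stand.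

The next compound is compound 4 `Nc1nc(N2CCCC2)c2ncn(/C=C3/CC3(CO)CO)c2n1`, which carries pyrrolidin-1-yl in place of benzylamino on an aromatic carbon of the shared core.

The measured steps closest to this change are a step that the two limits leave unreadable from compound 1 to compound 3 and a step that the two limits leave unreadable from compound 2 to compound 3 as both exchange the group on that aromatic carbon. The remaining step, a step that the two limits leave unreadable from compound 1 to compound 2, alters the same substituent further out. No size or direction can be read from any of the three because of the limit of > 300000 nM in this assay, at which 3 of the 3 values shown sit, and so none gives a measured guide.

Across compounds 1, 2 and 3, no group at this carbon has yet given a number, and none of them goes against that. No step beyond the usual scatter is therefore expected in this assay, in either direction. The estimated step is a number no higher from compound 3 to compound 4 (the limit leaves the size open) and a report at the limit is expected. For compound 4 the estimated value is 300000 nM with an expected range from 100000 nM to 300000 nM as the working figure.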

Compound 4, half-maximal cytotoxic concentration: > 300000 nM
Compound 4: only a limit was reported (the forecaster's own chance of this, stated with the estimate: 80%); the middle value lies on the limit itself.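

In this assay compound 4 gives > 300000 nM as a limit and not a number. No step from compound 1, compound 2 or compound 3 to compound 4 can be read, because all four compounds report only a limit: the limit of > 300000 nM in this assay, at which 4 of the 4 values shown sit.

The compounds shown leave open whether any group on this aromatic carbon of the shared core changes the half-maximal cytotoxic concentration, and in which direction.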